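The source may hold more compounds than are shown below. What is called first, only, known or untested is meant among the compounds shown, and "the series" means these compounds.

Among the measured compounds shown here, compound 2, `CN(C)C(=O)c1cccnc1NCCCN1CCN(c2ccccc2)CC1`, is one of two compounds measured in an assay on isolated protein for displacement of a labelled ligand from Alpha-1A adrenergic receptor (Bos taurus); a higher number here means a weaker inhibitor, a lower number a stronger inhibitor. In this assay compound 2 gives 2 nM, the higher of the two numbers. Its nearest neighbour is compound 1, `COc1ccccc1N1CCN(CCCNc2ccncc2C(=O)N(C(C)C)C(C)C)CC1`, which in this assay gives 1.59 nM; the gap between compound 2 and compound 1 lies within the scatter, so the two cannot be told apart on these numbers. Compound 3, `CN(C)C(=O)c1cccnc1NCCCN1CCN(c2ccccc2OCC(C)(C)C)CC1`, has not yet been measured in this assay. The change from compound 2 to compound 3 is neopentyloxy in place of hydrogen on an aromatic carbon. For the measured compounds named here, no step between two measured compounds that differ in just this way is available, so the size and direction of this change can only be guessed. Compound 1, which also carries an alkoxy group and gives 1.59 nM in this assay, suggests that an ether at this position is at least tolerated. Compound 3 is therefore expected to give 1.5 nM in this assay, within the range 0.4 nM to 6 nM, which means an expected step of a 1.3-fold lower number from compound 2 to compound 3 (0.12 log units; within the scatter) that stays within the scatter.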

Compound 3, inhibition constant: 0.794 nM
Beside the measured number, compound 3's estimate is 1.9-fold (0.28 log units) above it, within the range that was stated.
By their numbers in this assay, from the lowest: compounds 3, 1 and 2 (each within the scatter of the next, the first and the last beyond it).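

In this assay, among the compounds shown here, neopentyloxy in place of hydrogen on this aromatic carbon gives a 2.5-fold lower number from compound 2 to compound 3 (0.40 log units; beyond the scatter), the first step at this position that can be read; it is modest in size but lies beyond the scatter. The result shows that this position on the six-membered aromatic ring of carbon only accepts a group with no ring and no hydrogen-bond donor, and that the number goes down rather than up when this group enters. Nothing among the data given bears on what lies behind this step.

With neopentyloxy as the only group tested in this series on this carbon, the compounds shown leave open whether the step belongs to this particular group or would also appear with ethoxy, benzyloxy, a chlorine atom or a primary amine in its place. They also leave open whether neopentyloxy would give a step of the same direction and size on another carbon of the same ring, or with a longer chain in place of the one that links the two ring systems of compound 3.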